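Adding a Second Chloro to Compound 3

The source may report more compounds than this note shows. Statements on the series, on what has been measured and on what is new or still open speak of the compounds shown alone.

Measured in a functional assay on SW-620 cells (Homo sapiens); a higher number here means a weaker inhibitor of growth, a lower number a stronger inhibitor of growth:
Compound 1 `O=S(=O)(/C=C/c1ccc(Cl)cc1Cl)Cc1ccc(Nc2ncnc3ccccc23)cc1` gives 14000 nM
Compound 2 `O=S(=O)(/C=C/c1ccc(Cl)c(Cl)c1)Cc1ccc(Nc2ncnc3ccc(Br)cc23)cc1` gives 5000 nM
Compound 3 `O=S(=O)(/C=C/c1ccc(Cl)cc1)Cc1ccc(Nc2ncnc3ccc(Br)cc23)cc1` gives 45000 nM

Compound 3 has the highest number of the three, so it is the weakest inhibitor of growth in the set, and both other compounds lie beyond the scatter from it. Compound 4 `O=S(=O)(/C=C/c1ccc(Cl)cc1Cl)Cc1ccc(Nc2ncnc3ccc(Br)cc23)cc1` is not yet measured. It differs from compound 3 by chloro in place of hydrogen on an aromatic carbon in a change that reads chloro in place of hydrogen on an aromatic carbon, turning 4-chlorophenyl into 2,4-dichlorophenyl.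

For the measured compounds named here, one measured step bears directly on this, a 9.0-fold higher number from compound 2 to compound 3 (0.95 log units; beyond the scatter) on losing a chloro. The new step runs the opposite way, so it points towards a lower number, but the chloro in compound 2 does not sit where the new one would. That step can therefore guide the direction better than the size. Compound 1 already carries the 2,4-dichlorophenyl group on a different core, and compound 1 gives 14000 nM as a further hint, a number lower than that of compound 3. A somewhat smaller gain than the measured one is therefore expected. The expected change is a 5.0-fold lower number from compound 3 to compound 4 (0.70 log units; beyond the scatter) and would lie beyond the scatter. Compound 4 is estimated at 9000 nM with an expected range from 3000 nM to 25000 nM for the coming measurement.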

Compound 4, concentration for 50% growth inhibition: > 100000 nM
Compound 4: only a limit was reported; the forecaster's own chance of this, stated with the estimate: 5%; middle value at least 11-fold (1.04 log units) from the limit.
By their numbers in this assay, from the lowest: compound 2; then compound 1; then compound 3. At a limit, above all of these: compound 4.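

Compound 4 gives only a limit in this assay, not a number: the limit of > 100000 nM in this assay, at which 1 of the 4 values shown sits. At this aromatic carbon, ortho to a large group and meta to a chloro group, chloro in place of hydrogen gives an at least 2.2-fold higher number from compound 3 to compound 4 (0.34 log units; beyond the scatter), whereas the chloro lost from the 3,4-dichlorophenyl group gives a 9.0-fold higher number from compound 2 to compound 3 (0.95 log units; beyond the scatter), so adding a second chloro to the 4-chlorophenyl group does not act in one direction but depends on where it sits. The same placing shows when 2,4-dichlorophenyl stands in place of 3,4-dichlorophenyl, with an at least 20-fold higher number from compound 2 to compound 4 (1.30 log units; beyond the scatter), and bromo in place of hydrogen on the core, with the 2,4-dichlorophenyl group kept, gives an at least 7.1-fold higher number from compound 1 to compound 4 (0.85 log units; beyond the scatter), so the number of compound 1, 14000 nM, did not carry over to the bromo-bearing core.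

As far as these compounds go, how far compound 4 truly lies past its limit stays open, so the full size of these steps is unknown. Also open, from the compounds shown here alone, is whether a fluoro or a methoxy on this same carbon would shift the number in the same way, and how the 4-chlorophenyl group behaves on the core of compound 1, which would show whether bromo and the second chloro act together.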